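Carbamate ring replacement on a pyrazole-based ligand

The compounds below may be only part of what the source reports. "The series", "measured", "known", "first", "only" and "open" are said of these compounds alone.

Of the compounds shown here, three sharing one core have been measured in an assay on CHO-K1 cells for displacement of a labelled ligand from prostaglandin E2 receptor EP1 subtype (Homo sapiens); on this read-out lower numbers stand for stronger inhibition and higher numbers for weaker inhibition. Compound 1 `CNC(=O)c1cc(C)n(Cc2cc(Cl)ccc2OCc2ccccc2)n1` gives 100 nM. Compound 2 `Cc1cc(NC(=O)CC2CCCCC2)nn1Cc1cc(Cl)ccc1OCc1ccccc1` gives 6.31 nM. Compound 3 `COC(=O)Nc1cc(C)n(Cc2cc(Cl)ccc2OCc2ccccc2)n1` gives 200 nM, the highest number of the three, though its gap to compound 1 lies within the usual scatter, as the step of a 2.0-fold higher number from compound 1 to compound 3 (0.30 log units; within the scatter) shows. The step of a 32-fold higher number from compound 2 to compound 3 (1.50 log units; beyond the scatter) is large and beyond the scatter.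

Compound 4 `Cc1cc(NC(=O)O[C@H]2CCOC2)nn1Cc1cc(Cl)ccc1OCc1ccccc1` differs from compound 3 by oxolan-3-yl in place of methyl on an oxygen next to a carbonyl group. Among the measured compounds shown here, the only measured step touching this region is a 32-fold higher number from compound 2 to compound 3 (1.50 log units; beyond the scatter), where a ring-bearing group in place of methoxy on the carbonyl carbon went with a much lower number; compound 4 instead keeps the carbamate oxygen and adds an oxolane ring there, so that step bears on it only loosely. A moderate drop is expected, but smaller than that seen for compound 2.

Compound 4 is therefore estimated at 60 nM, within 20 nM to 200 nM, meaning an expected step of a 3.3-fold lower number from compound 3 to compound 4 (0.52 log units; beyond the scatter).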

Compound 4, half-maximal inhibitory concentration in the prostaglandin E2 receptor EP1 subtype assay: 79.4 nM
Beside the measured number, compound 4's estimate is 1.3-fold (0.12 log units) below it; the range from low to high includes it.
By their numbers in the prostaglandin E2 receptor EP1 subtype assay, from the lowest: compound 2; then compounds 4, 1 and 3 (each within the scatter of the next, the first and the last beyond it).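

Putting a ring on the oxygen next to the carbonyl is tolerated and even helps: in the prostaglandin E2 receptor EP1 subtype assay compound 4 gives 79.4 nM. In the prostaglandin E2 receptor EP1 subtype assay, oxolan-3-yl in place of methyl goes with a 2.5-fold lower number from compound 3 to compound 4 (0.40 log units; beyond the scatter). Still, in the prostaglandin E2 receptor EP1 subtype assay the gain closes little of the distance to the best compound, leaving a 13-fold higher number from compound 2 to compound 4 (1.10 log units; beyond the scatter), and the carbamate only draws level with the first compound, at a 1.3-fold lower number from compound 1 to compound 4 (0.10 log units; within the scatter). In a physicochemical assay for lipophilicity, at pH 7.4 (on this read-out lower numbers stand for lower lipophilicity and higher numbers for higher lipophilicity), compound 3 has > 3.7, which is a limit of the assay and not a number. In the physicochemical assay compound 4 gives 2.7. In the physicochemical assay the same change goes with a number at least 1.00 log units lower from compound 3 to compound 4 (beyond the scatter), so the lower binding number comes with lower lipophilicity, although compound 3 stands at a limit of the assay and not at a number: the limit of > 3.7 in the physicochemical assay, at which 1 of the 2 values shown sits.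

Going by these compounds, whether the mirror-image form of oxolan-3-yl would give the same result stays open. So does the effect of a cyclohexyl group on this oxygen, which would show whether the oxygen in the oxolane ring matters.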